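The compounds below may be only part of what the source reports. "The series", "measured", "known", "first", "only" and "open" are said of these compounds alone.

Measured compounds:
compound 1 `COc1cc(C)cc(-c2c(-c3ccnc(-c4ccc(C(C)=O)cc4)c3)cnn2CC#N)c1`, > 100000 nM
compound 2 `Cc1cc(O)cc(-c2nn(CC#N)cc2-c2ccnc(-c3ccc(N(C)C)cc3)c2)c1`, 6080 nM

In a functional assay on NCI-H322M cells (Homo sapiens) for inhibition, read by sulforhodamine B assay, with a stated time of 48 h (a lower number here means a stronger inhibitor of growth, a higher number a weaker inhibitor of growth), compound 1 gives only a limit, > 100000 nM, and no number behind it; it sits at the limit of > 100000 nM in this assay, at which 1 of the 2 values shown sits. In this assay compound 2 gives 6080 nM. Compound 3 `COc1cc(C)cc(-c2c(-c3ccnc(-c4ccc(N(C)C)cc4)c3)cnn2CC#N)c1` carries the change (dimethylamino in place of acetyl on an aromatic carbon), dimethylamino in place of acetyl on an aromatic carbon. Compound 2 bears the same dimethylamino group and reaches a measured value. For compound 3 the expected step is an at least 5.0-fold lower number from compound 1 to compound 3 (0.69 log units; beyond the scatter), toward stronger growth inhibition and beyond the scatter. For compound 3 the estimate is 20000 nM, within 5000 nM to 100000 nM.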

Compound 3, concentration for 50% growth inhibition: 331 nM
Estimate against measurement, compound 3: 60-fold (1.78 log units) above; measured number outside the range, below it.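

In this assay, dimethylamino in place of acetyl on an aromatic carbon gives an at least 300-fold lower number from compound 1 to compound 3 (2.48 log units; beyond the scatter), so this single position separates a compound with a measured number from one without. Compound 1 gives only a limit, > 100000 nM. The printed size of the step is therefore a minimum, and its true size stays unknown: the limit of > 100000 nM in this assay, at which 1 of the 3 values shown sits.

Open, going by these compounds, is whether the lower number depends on both methyl groups on the nitrogen. An unsubstituted amino group, a morpholine or a methoxy group at the same place would test this.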